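Aryl-for-aryl swap on the shared core: Vero cytotoxicity

The source may report more compounds than this note shows. Statements on the series, on what has been measured and on what is new or still open speak of the compounds shown alone.

Compound 1 `COc1nc(C2CCCCC2)ccc1[C@@H](c1ccccc1)[C@@](O)(CCN(C)C)c1cccc2ccccc12` carries a cyclohexyl on the shared core; in a toxicity assay on Vero cells (Chlorocebus sabaeus) for cytotoxicity (on this read-out lower numbers stand for higher toxicity in this test and higher numbers for lower toxicity in this test), compound 1 gives 32.3 ug/mL. Compound 2 `COc1nc(-c2ccccc2Cl)ccc1[C@@H](c1ccccc1)[C@@](O)(CCN(C)C)c1cccc2ccccc12` carries a 2-chlorophenyl at the same position. In this assay compound 2 reaches only the limit > 50 ug/mL, not a number. Within the data shown here, the one measured step, an at least 1.5-fold higher number from compound 1 to compound 2 (0.18 log units; that floor lies within the scatter), sits at the floor set by the limit of > 50 ug/mL in this assay, at which 1 of the 2 values shown sits, so its true size is unknown beyond that floor.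

Compound 3 `COc1nc(-c2cnsc2)ccc1[C@@H](c1ccccc1)[C@@](O)(CCN(C)C)c1cccc2ccccc12` differs from compound 2 by 1,2-thiazol-4-yl in place of 2-chlorophenyl on an aromatic carbon. Among the measured compounds shown here, no measured step covers this particular exchange; the step from compound 1 to compound 2 only shows that replacing the group at this position moved this read-out little, if at all. The expectation for the step from compound 2 to compound 3 is therefore an at least 1.1-fold lower number from compound 2 to compound 3 (0.04 log units; that floor lies within the scatter), none beyond the scatter. The estimate for compound 3 in this assay is 45 ug/mL, expected between 20 ug/mL and 90 ug/mL.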

Compound 3, half-maximal cytotoxic concentration: 26.3 ug/mL
For compound 3 the middle estimate is 1.7-fold (0.23 log units) above the measured one; the range from low to high includes it.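

Swapping cyclohexyl for 1,2-thiazol-4-yl gives a 1.2-fold lower number from compound 1 to compound 3 (0.09 log units; within the scatter), so in this assay this place next to the ring nitrogen shows no separation between compound 1 and a five-membered aromatic ring with 2 hetero atoms in compound 3. Against the 2-chlorophenyl group the change gives an at least 1.9-fold lower number from compound 2 to compound 3 (0.27 log units; that floor lies within the scatter), and compound 2 stands at a limit rather than a number, so only a floor can be read: the limit of > 50 ug/mL in this assay, at which 1 of the 3 values shown sits. No step among these three groups is yet printed beyond the scatter, though the true size of both steps involving compound 2 remains unknown.

On these data alone, how an amine, a carboxylic acid or a longer alkyl chain at this place would read in this assay remains open. Also open, as far as these compounds go, is whether replacing the methoxy group with a hydroxyl would move this read-out.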